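Methylsulfonyl for Sulfamoyl on a Benzothiazolyl-Aminopyrimidine Series

The compounds below may be only part of what the source reports. "The series", "measured", "known", "first", "only" and "open" are said of these compounds alone.

In a functional assay on MDA-MB-231 cells (Homo sapiens) for antiproliferative activity, read by MTT assay, with a stated time of 48 h (a higher number here means a weaker inhibitor, a lower number a stronger inhibitor), three compounds of one series have been measured. Compound 1 `Cc1cnc(Nc2ccc(S(C)(=O)=O)cc2)nc1Nc1nc2ccc(Cl)cc2s1` gives 5900 nM. Compound 2 `Cc1cnc(Nc2ccc(S(N)(=O)=O)cc2)nc1Nc1nc2ccc(Cl)cc2s1` gives 9420 nM. Compound 3 `COc1ccc2nc(Nc3nc(Nc4ccc(S(N)(=O)=O)cc4)ncc3F)sc2c1` gives 26600 nM, the highest of the three numbers, beyond the scatter from both of the others. The difference between the core of compound 3 and that of compound 2 is not broken down here.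

One change is seen twice. From compound 2 to compound 1 it is methyl in place of amino on a sulfonyl sulfur, and it made a step of a 1.6-fold lower number from compound 2 to compound 1 (0.20 log units; within the scatter). From compound 3 to compound 4 `COc1ccc2nc(Nc3nc(Nc4ccc(S(C)(=O)=O)cc4)ncc3F)sc2c1`, not yet measured, the same change is made: methyl in place of amino on a sulfonyl sulfur.

In this assay, compound 4 is expected to give about 17000 nM, with an estimated range from 7000 nM to 40000 nM. The expected step is a 1.6-fold lower number from compound 3 to compound 4 (0.19 log units; within the scatter). Within the data shown here, this estimate rests on the single earlier instance, in which the step was a 1.6-fold lower number from compound 2 to compound 1 (0.20 log units; within the scatter); with only one precedent, a step of similar modest size is expected.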

Compound 4, half-maximal inhibitory concentration: 4740 nM
Compound 4: the middle estimate sits 3.6-fold (0.55 log units) above what was measured; measured number below the stated range.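

In this assay, methyl in place of amino on a sulfonyl sulfur gave a 5.6-fold lower number from compound 3 to compound 4 (0.75 log units; beyond the scatter). Set beside the earlier step, the change did not carry over at one size from one core to the other: the same change on two cores in this assay, a 1.6-fold lower number (0.20 log units; within the scatter) from compound 2 to compound 1 and a 5.6-fold lower number (0.75 log units; beyond the scatter) from compound 3 to compound 4, 3.5-fold (0.55 log units) apart, beyond the scatter of two such steps. Among these compounds, only the step on the core of compound 3 lies beyond the scatter, so the change cannot be said to lower the number across this series as a whole, and two pairs do not show what sets the size of the step on either core.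

The cores of compound 2 and compound 3 differ in more than one place, and the compounds shown leave open which of those differences goes with the larger step. Also open, as far as these compounds go, is how another group on the sulfonyl sulfur, such as ethyl or dimethylamino, would behave on either core in this assay.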